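The source may hold more compounds than are shown below. What is called first, only, known or untested is meant among the compounds shown, and "the series" means these compounds.

Measured so far in an ADME assay on microsomes from liver (Mus musculus, strain CD-1) for metabolic stability, read by LC-MS, tested at 2 uM; on this read-out lower numbers stand for a shorter-lived compound and higher numbers for a longer-lived compound:
- Compound 1 `Cn1ccc2ccc(-c3cc(Nc4cnccc4C(=O)NCc4cncnc4)cc4nccnc34)cc21`: 0.4 h
- Compound 2 `CC(=O)N1CCC(NC(=O)c2ccncc2Nc2cc(-c3ccc4ccn(C)c4c3)c3nccnc3c2)CC1`: 0.117 h

Compound 2 holds the lower of these two numbers. Compound 3 `Cn1ccc2ccc(-c3cc(Nc4cnccc4C(=O)NC4CCNC(=O)C4)cc4nccnc34)cc21` departs from compound 2 on an amide-type nitrogen: 2-oxopiperidin-4-yl in place of 1-acetylpiperidin-4-yl on an amide-type nitrogen. For the measured compounds named here, one measured step bears on that place, a 3.4-fold lower number from compound 1 to compound 2 (0.53 log units; beyond the scatter), which is modest but beyond the scatter. Going by the values given here, it involved a different incoming group, so it shows only that changes here can register in this assay. With compound 2 the lower of the two, a modest rise is expected, and the expected size is a 1.9-fold higher number from compound 2 to compound 3 (0.27 log units; within the scatter). The estimate for compound 3 is 0.22 h, with a range of 0.09 h to 0.5 h.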

Compound 3, half-life: > 1 h
Compound 3 was reported as a limit; the forecaster's own chance of this, stated with the estimate: 3%; at least 4.5-fold (0.65 log units) between middle value and limit.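

In this assay, the group on the amide-type nitrogen can lengthen the half-life as well as shorten it: 2-oxopiperidin-4-yl in place of 1-acetylpiperidin-4-yl gives an at least 8.5-fold higher number from compound 2 to compound 3 (0.93 log units; beyond the scatter), and in place of (pyrimidin-5-yl)methyl it gives an at least 2.5-fold higher number from compound 1 to compound 3 (0.39 log units; beyond the scatter). Compounds 2 and 3 both carry a six-membered non-aromatic ring with one hetero atom here, so that ring alone does not set the read-out. Compound 3 is reported only as a limit, > 1 h, and both steps are therefore minimum sizes: the limit of > 1 h in this assay, at which 1 of the 3 values shown sits.

Going by these compounds, how far compound 3 lies past its limit remains open. So does whether a piperidin-4-yl with a free amine would keep the longer half-life on this nitrogen.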